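A few compounds are considered here, and "the series" means these few. Any claim that something is new, unique, unknown or untested is made for them only; others in the source may bear on it.

Compound 1 `Oc1ccc(-c2cc(-c3ccc(Cl)cc3)nc(-c3cccnc3)c2)cc1` stands highest of the two numbers measured in an assay on isolated protein for inhibition of DNA topoisomerase 1 (Homo sapiens), with a stated time of 30 min, tested at 100 uM (on this read-out higher numbers stand for a stronger effect at the one concentration tested and lower numbers for a weaker effect), where compound 1 gives 18.8%. Compound 2 `Oc1cccc(-c2cc(-c3ccc(Cl)cc3)nc(-c3cccnc3)c2)c1` gives 2.8% in this assay; the step of a number 16 percentage points lower from compound 1 to compound 2 (beyond the scatter) is the only one measured so far. Compound 3 `Oc1ccc(-c2cc(-c3ccc(Cl)cc3)nc(-c3ccco3)c2)cc1` carries the change (furan-2-yl in place of pyridin-3-yl on an aromatic carbon). Among the compounds with values here, no measured step bears on this change, since the one known step concerns the hydroxyphenyl group, not the pyridin-3-yl. The expected step of a number 3.8 percentage points lower from compound 1 to compound 3 (within the scatter) is therefore set small, with no direction beyond the scatter. In this assay compound 3 is expected to give 15%, within the range 0% to 35%.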

Compound 3, a percentage reported as inhibition, at one concentration (the size of the read-out at that concentration, not a potency): 15.8%
The estimate for compound 3 lay 0.8 percentage points below the measured number; the measured number falls inside the stated range.
By their numbers in this assay, from the lowest: compound 2; then compounds 3 and 1 (each within the scatter of the next).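

In this assay, furan-2-yl in place of pyridin-3-yl next to the ring nitrogen gives a number 3 percentage points lower from compound 1 to compound 3 (within the scatter), so pyridin-3-yl is not required at this position for a number at the level of compound 1. Within the data shown here, this is the first measured change at this position, and the five-membered aromatic ring serves here alongside the six-membered one. Nothing measured on these compounds explains this result.

Open, as far as these compounds go, is how a non-aromatic group at this position, such as an amine or a carboxylic acid, would read. Also open, from the compounds shown here alone, is whether 3-hydroxyphenyl in place of 4-hydroxyphenyl would carry the same step alongside furan-2-yl.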